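The compounds below may be only part of what the source reports. "The series", "measured", "known", "first", "only" and "open" are said of these compounds alone.

Measured in a functional assay on BT-20 cells (Homo sapiens) for cytotoxicity, read by MTT assay, with a stated time of 68 h; on this read-out higher numbers stand for weaker inhibition and lower numbers for stronger inhibition
compound 1 `O=C(/C=C/c1cccc(OCc2ccccc2)c1)c1ccc([N+](=O)[O-])cc1` gives 80900 nM
compound 2 `Cc1ccc(C(=O)/C=C/c2cccc(OCc3ccccc3)c2)cc1` gives 61000 nM
compound 3 `O=C(/C=C/c1cccc(OCc2ccccc2)c1)c1ccccc1Br` gives 1800 nM

Compound 3 has the lowest number of the three and is the strongest inhibitor of this small set. The next step leads to compound 4 (`O=C(/C=C/c1cccc(OCc2ccccc2)c1)c1cccc(Br)c1`), with 3-bromophenyl in place of 2-bromophenyl on a carbonyl carbon. Among the measured compounds shown here, two measured steps bear on this: a 45-fold lower number from compound 1 to compound 3 (1.65 log units; beyond the scatter) and a 34-fold lower number from compound 2 to compound 3 (1.53 log units; beyond the scatter) are both large, while a 1.3-fold lower number from compound 1 to compound 2 (0.12 log units; within the scatter) stays within the scatter. The aryl group on the carbonyl carbon can therefore move the number strongly in this series. However, only compound 3 (1800 nM) carries bromine, and no measured compound carries 3-bromophenyl, so the data do not show how much of that low number compound 4 would keep. A move to a higher number, beyond the scatter but smaller than the large steps, is expected, and the estimated step is a 5.0-fold higher number from compound 3 to compound 4 (0.70 log units; beyond the scatter) on this basis. Compound 4 is estimated at 9000 nM (expected range 2000 nM to 45000 nM).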

Compound 4, half-maximal inhibitory concentration: 7100 nM
Compound 4: middle estimate off by 1.3-fold (0.10 log units), on the high side, and the stated range covers the measured number.
By their numbers in this assay, from the lowest: compound 3; then compound 4; then compounds 2 and 1 (each within the scatter of the next).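

In this assay, 3-bromophenyl in place of 2-bromophenyl on the carbonyl carbon gives a 3.9-fold higher number from compound 3 to compound 4 (0.60 log units; beyond the scatter), so with the same atoms, the arrangement of the bromophenyl group alone moves the number beyond the scatter. The low numbers are not confined to 2-bromophenyl: 3-bromophenyl still gives an 8.6-fold lower number from compound 2 to compound 4 (0.93 log units; beyond the scatter) and an 11-fold lower number from compound 1 to compound 4 (1.06 log units; beyond the scatter), though these steps are read only within this small set. No measurement here accounts for the gap between the two bromophenyl groups.

Compound 1 and compound 2 carry different groups from the bromophenyl compounds, so the share of bromine itself in these steps remains unresolved. Going by these compounds, whether a chlorophenyl, aminophenyl or methoxyphenyl group on the carbonyl carbon would reach similar numbers also stays open.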